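Another Aryl Variant on the Ring Nitrogen

A few compounds are considered here, and "the series" means these few. Any claim that something is new, unique, unknown or untested is made for them only; others in the source may bear on it.

Three compounds share one core and differ only in the aryl group on an aromatic nitrogen. In a functional assay on HepG2 cells (Homo sapiens) for inhibition, read by MTT assay, with a stated time of 72 h (on this read-out higher numbers stand for weaker inhibition and lower numbers for stronger inhibition), compound 1 `N#Cc1ccc(-n2cc(COc3cccc(NC(=O)Nc4ccc(Cl)c(C(F)(F)F)c4)c3)nn2)cc1` gives 2980 nM, compound 2 `O=C(Nc1cccc(OCc2cn(-c3ccc(Cl)cc3)nn2)c1)Nc1ccc(Cl)c(C(F)(F)F)c1` gives 2490 nM, and compound 3 `O=C(Nc1cccc(OCc2cn(-c3cccc(I)c3)nn2)c1)Nc1ccc(Cl)c(C(F)(F)F)c1` gives 4780 nM, the top of these three numbers, although a 1.6-fold higher number from compound 1 to compound 3 (0.21 log units; within the scatter) and a 1.9-fold higher number from compound 2 to compound 3 (0.28 log units; within the scatter) both lie inside the scatter. Compound 4 `COc1ccccc1-n1cc(COc2cccc(NC(=O)Nc3ccc(Cl)c(C(F)(F)F)c3)c2)nn1` changes the same place once more: 2-methoxyphenyl in place of 3-iodophenyl on an aromatic nitrogen. The two earlier swaps at this nitrogen bear on it, and since neither moved the number beyond the scatter, no step beyond the scatter is expected here either, a 1.4-fold lower number from compound 3 to compound 4 (0.14 log units; within the scatter). Compound 4 is therefore estimated at 3500 nM in this assay, with a range from 1500 nM to 8000 nM.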

Compound 4, half-maximal inhibitory concentration: 11300 nM
Compound 4: the middle estimate sits 3.2-fold (0.51 log units) below what was measured; the measured number lies above the stated range.
By their numbers in this assay, from the lowest: compounds 2, 1 and 3 (each within the scatter of the next); then compound 4.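

In this assay, among the compounds shown here, the aryl group on the ring nitrogen proves not to be interchangeable: 2-methoxyphenyl is the first group here to move the number beyond the scatter, with a 2.4-fold higher number from compound 3 to compound 4 (0.37 log units; beyond the scatter), a 4.5-fold higher number from compound 2 to compound 4 (0.66 log units; beyond the scatter) and a 3.8-fold higher number from compound 1 to compound 4 (0.58 log units; beyond the scatter), all modest steps. Compound 4 is thus the weakest of the four, while compounds 1, 2 and 3 remain within the scatter of one another. Nothing measured here accounts for this step. Going by these compounds, what remains open is whether an unsubstituted phenyl or a phenyl bearing an amine would stay with compounds 1, 2 and 3 or fall with compound 4.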